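A few compounds are considered here, and "the series" means these few. Any claim that something is new, unique, unknown or untested is made for them only; others in the source may bear on it.

Working notes on the series. Going by the values given here, compound 3 `COc1cc(-c2nn(-c3cccc(NC(=O)Nc4ccc(Cl)c(C(F)(F)F)c4)c3)cc2-c2ccncc2)ccc1Cl` gives 1100 nM in a functional assay on ACHN cells (Homo sapiens) for inhibition, read by sulforhodamine B assay, with a stated time of 48 h (a higher number here means a weaker inhibitor of growth, a lower number a stronger inhibitor of growth), the second highest of the three numbers measured so far. Compound 1 `COc1cc(-c2nn(-c3cccc(NC(=O)Nc4cccc(C(F)(F)F)c4)c3)cc2-c2ccncc2)ccc1Cl` gives 656 nM in this assay, and compound 2 `COc1cc(-c2nn(-c3cccc(NC(=O)c4ccc(Cl)c(C(F)(F)F)c4)c3)cc2-c2ccncc2)ccc1Cl` gives 2730 nM. Compound 4 `COc1cc(-c2nn(-c3cccc(NC(=O)c4ccccc4)c3)cc2-c2ccncc2)ccc1Cl` differs from compound 3 by phenyl in place of (4-chloro-3-(trifluoromethyl)phenyl)amino on a carbonyl carbon. Among the compounds with values here, two measured steps bear on this change: a 2.5-fold lower number from compound 2 to compound 3 (0.39 log units; beyond the scatter), whose reverse matches the loss of the amino link on the carbonyl carbon, and a 4.2-fold higher number from compound 1 to compound 2 (0.62 log units; beyond the scatter). The chloro on its own showed only a 1.7-fold higher number from compound 1 to compound 3 (0.22 log units; within the scatter). Both relevant steps point toward a higher number, so for compound 4 a modest rise is expected, a 3.2-fold higher number from compound 3 to compound 4 (0.50 log units; beyond the scatter). Compound 4 is therefore estimated at 3500 nM, with a range from 1200 nM to 10000 nM.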

Compound 4, concentration for 50% growth inhibition: 754 nM
Compound 4: the middle estimate sits 4.6-fold (0.67 log units) above what was measured, and the stated range ends above it.
By their numbers in this assay, from the lowest: compounds 1, 4 and 3 (each within the scatter of the next); then compound 2.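

In this assay, plain phenyl on the carbonyl carbon gives a 1.5-fold lower number from compound 3 to compound 4 (0.16 log units; within the scatter) and a 1.1-fold higher number from compound 1 to compound 4 (0.06 log units; within the scatter) as steps within the scatter, so neither the amino link nor the substituted aryl is required to hold this level. Replacing 4-chloro-3-(trifluoromethyl)phenyl on the same carbon gives a 3.6-fold lower number from compound 2 to compound 4 (0.56 log units; beyond the scatter) and so sets compound 2 apart from compound 4. No measurement at hand explains this difference and the reading stays descriptive.

Still open, going by these compounds, is whether an amine or a carboxylic acid on the phenyl of compound 4 would keep this level.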